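This account rests on a few compounds, and the source may have more. Where it says the series, first, only, none or still open, it means among the compounds named here.

Working notes on the series. Compound 1, `O=C1CC(c2ccccc2F)C(=O)N1CN1CCN(c2ccc(Cl)cc2)CC1`, is tested in a functional assay on the whole organism (strain CF-1 albino) with Mus musculus as the target, with a stated time of 4 h (on this read-out higher numbers stand for an effect only at larger amounts of compound and lower numbers for an effect already at smaller amounts), and gives 100 mg/kg. Compound 2, `O=C1CC(c2ccccc2Br)C(=O)N1CN1CCN(c2cccc(Cl)c2)CC1`, gives in this assay a value of 100 mg/kg; compound 1 thus stands level with compound 2 at the digits recorded, and the two values lie within the scatter of each other, so no order between them can be read. The next compound to be measured is compound 3, `O=C1CC(c2ccccc2Br)C(=O)N1CN1CCN(c2ccc(Cl)cc2)CC1`. It differs from compound 1 in one place: bromo in place of fluoro on an aromatic carbon. For the measured compounds named here, no measured pair in the set carries this same change, so the size of the step cannot be read from the data; the expectation is a step from compound 1 to compound 3 of no change at the digits printed from compound 1 to compound 3 (within the scatter), that is, none beyond the scatter, with compound 2 showing that a bromo analogue can sit at the same level. On that basis compound 3 is estimated to give in this assay about 100 mg/kg, with a range from 50 mg/kg to 200 mg/kg.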

Compound 3, minimum effective dose: 300 mg/kg
Compound 3: middle estimate off by 3.0-fold (0.48 log units), on the low side; the measured number lies above the stated range.
By their numbers in this assay, from the lowest: compounds 1 and 2 (each within the scatter of the next); then compound 3.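

In this assay, for the compounds shown here, bromo in place of fluoro on an aromatic carbon ortho to a large group gives a 3.0-fold higher number from compound 1 to compound 3 (0.48 log units; beyond the scatter), so the halogen at this position matters to the read-out, which the earlier compounds could not show. With bromo held in place, 4-chlorophenyl in place of 3-chlorophenyl on an amine nitrogen in a ring gives a 3.0-fold higher number from compound 2 to compound 3 (0.48 log units; beyond the scatter), so the chlorophenyl group matters as well, and in both steps compound 3 needs the larger amount. Nothing at hand bears on the reason for either step.

Still open, on these data alone, is whether bromo in place of fluoro gives a similar step when the amine nitrogen carries 3-chlorophenyl rather than 4-chlorophenyl. The compounds shown also leave open how a methoxy group or an amine would read at the position now holding the halogen.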